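The source may hold more compounds than are shown below. What is called first, only, known or untested is meant among the compounds shown, and "the series" means these compounds.

In a functional assay on A549 cells (Homo sapiens) for cytotoxicity, read by MTT assay, with a stated time of 72 h (a lower number here means a stronger inhibitor, a higher number a weaker inhibitor), three compounds have been measured so far:
compound 1 `O=C(N/N=C/c1ccc(O)cc1)Nc1cc2c(Nc3ccc(F)c(Cl)c3)ncnc2cc1O[C@H]1CCOC1` gives 1320 nM
compound 2 `COc1cc2ncnc(Nc3ccc(F)c(Cl)c3)c2cc1NC(=O)N/N=C/c1cccc(Br)c1` gives 28100 nM
compound 3 `COc1cc2ncnc(Nc3ccc(F)c(Cl)c3)c2cc1NC(=O)N/N=C/c1ccc(OC)c(OC)c1OC` gives 32800 nM

Compound 3 (32800 nM) lies within the scatter of compound 2 (28100 nM), and both stand well above compound 1 (1320 nM). Next is compound 4 `COc1cc2ncnc(Nc3ccc(F)c(Cl)c3)c2cc1NC(=O)N/N=C/c1ccc(O)cc1` which has 4-hydroxyphenyl in place of 2,3,4-trimethoxyphenyl on a carbon with a double bond to nitrogen. For the measured compounds named here, the one measured step at this place (a 1.2-fold higher number from compound 2 to compound 3 (0.07 log units; within the scatter)) stayed within the scatter, so it gives no reason to expect a large shift. Going by the values given here, compound 1 (1320 nM) carries the same 4-hydroxyphenyl, but on a different core, and no measured pair separates the group from the core. Only part of that gap is therefore expected to carry over, and a moderately lower number is expected in this assay (estimated as a 2.3-fold lower number from compound 3 to compound 4 (0.37 log units; beyond the scatter)). The estimate for compound 4 is 14000 nM (expected range 3000 nM to 35000 nM).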

Compound 4, half-maximal inhibitory concentration: 7610 nM
Estimate against measurement, compound 4: 1.8-fold (0.26 log units) above; the measured number falls inside the stated range.
By their numbers in this assay, from the lowest: compound 1; then compound 4; then compounds 2 and 3 (each within the scatter of the next).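

In this assay, the group on a carbon with a double bond to nitrogen now makes a difference: 4-hydroxyphenyl gives a 4.3-fold lower number from compound 3 to compound 4 (0.63 log units; beyond the scatter) and a 3.7-fold lower number from compound 2 to compound 4 (0.57 log units; beyond the scatter), whereas the 3-bromophenyl to 2,3,4-trimethoxyphenyl change gave only a 1.2-fold higher number from compound 2 to compound 3 (0.07 log units; within the scatter). With 4-hydroxyphenyl held constant, the group on an oxygen on an aromatic ring can also be read on its own: methyl in place of oxolan-3-yl gives a 5.8-fold higher number from compound 1 to compound 4 (0.76 log units; beyond the scatter), so part of the earlier gap to compound 1 belongs to this second place. Nothing available explains either step.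

Going by these compounds, whether 4-methoxyphenyl, 4-aminophenyl or unsubstituted phenyl on that carbon would give a number like that of compound 4 stays open. Also open, on these data alone, is whether oxolan-3-yl in place of methyl would shift the 3-bromophenyl and 2,3,4-trimethoxyphenyl compounds in the same way.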